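A few compounds are considered here, and "the series" means these few. Any claim that something is new, unique, unknown or untested is made for them only; others in the source may bear on it.

Measured compounds:
Compound 1, `CC(=O)Nc1cnc2[nH]c(=O)n([C@H]3CC[C@@H](C(C)C)CC3)c(=O)c2c1`: 10 mL.min-1.g-1
Compound 2, `CC[C@H]1CC[C@@H](n2c(=O)[nH]c3ncc(NC(C)=O)cc3c2=O)CC1`: 2.7 mL.min-1.g-1
Compound 3, `CC(C)[C@H]1CC[C@H](n2c(=O)[nH]c3ncc(N)cc3c2=O)CC1`: 1.9 mL.min-1.g-1

All three numbers come from an ADME assay on microsomes from liver (Mus musculus, strain CD1) for metabolic stability, read by HPLC, using NADPH, with a stated time of 30 min, tested at 0.5 uM; on this read-out higher numbers stand for fast clearance and lower numbers for slow clearance. Compound 2 differs from compound 1 in one place only: hydrogen in place of methyl on a saturated chain carbon bound to a saturated chain carbon and a saturated ring carbon. That change brought a 3.7-fold lower number from compound 1 to compound 2 (0.57 log units; beyond the scatter). Compound 3 sits on a different core, and the difference between the cores of compound 1 and compound 3 is not broken down here. The number for compound 3 lies within the scatter of compound 2 and well below that of compound 1.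

Compound 4, `CC[C@H]1CC[C@H](n2c(=O)[nH]c3ncc(N)cc3c2=O)CC1`, has not yet been measured. It differs from compound 3 in the same place and the same way as compound 2 differs from compound 1: hydrogen in place of methyl on a saturated chain carbon bound to a saturated chain carbon and a saturated ring carbon. Because the earlier step was a 3.7-fold lower number from compound 1 to compound 2 (0.57 log units; beyond the scatter), a step in the same direction is expected from compound 3 to compound 4, though likely smaller since compound 3 starts from 1.9 mL.min-1.g-1 already. The expected step from compound 3 to compound 4 is a 2.1-fold lower number from compound 3 to compound 4 (0.32 log units; beyond the scatter). The estimate for compound 4 is therefore 0.9 mL.min-1.g-1, most likely between 0.3 mL.min-1.g-1 and 2.5 mL.min-1.g-1.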

Compound 4, intrinsic clearance in microsomes in the Mus musculus assay: 0.9 mL.min-1.g-1
Compound 4: middle estimate and measured number agree at the digits printed; the range from low to high includes it.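

In the Mus musculus assay, putting ethyl in place of isopropyl gave a 2.1-fold lower number from compound 3 to compound 4 (0.32 log units; beyond the scatter), so the change carried over to the second core in direction and, given the usual scatter, in size: the same change on two cores in the Mus musculus assay, a 3.7-fold lower number (0.57 log units; beyond the scatter) from compound 1 to compound 2 and a 2.1-fold lower number (0.32 log units; beyond the scatter) from compound 3 to compound 4, 1.8-fold (0.24 log units) apart, within the scatter of two such steps. For the compounds shown here, this rests on only two matched pairs, so it does not show that the change would behave the same way on any other core, and it says nothing about why the number drops. In a physicochemical assay for solubility, read by nephelometry, measured as kinetic solubility (a lower number here means a less soluble compound, a higher number a more soluble compound), compound 3 gives 25000 nM and compound 4 gives 55000 nM, and only the core of compound 3 offers a pair, so whether this step would carry over to the core of compound 1 cannot be judged: the measured solubility of compound 3, 25000 nM, and of compound 4, 55000 nM, a 2.2-fold higher number (0.34 log units; beyond the scatter).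

The compounds shown carry only isopropyl or ethyl in this place, so it remains open how a shorter methyl or a longer chain such as butyl would read in either assay. A chain ending in an amine or a carboxylic acid in the same place is also left open.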